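Cyanoamidine series: shortening the chain from compound 3 to compound 4

The source may hold more compounds than are shown below. What is called first, only, known or untested is meant among the compounds shown, and "the series" means these compounds.

Measured so far in a physicochemical assay for lipophilicity, read by HPLC, using the shake flask method; on this read-out higher numbers stand for higher lipophilicity and lower numbers for lower lipophilicity:
compound 1, `C/C(=N\C#N)N(Cc1ccc(Cl)nc1)C(C)C`: 1.46
compound 2, `C/C(=N\C#N)NCc1ccc(Cl)nc1`: 1.07
compound 3, `CCCCC/C(=N\C#N)N(C)Cc1ccc(Cl)nc1`: 2.3

Compound 3 stands highest of the three numbers in this assay. Its nearest neighbour is compound 1, which reads lower by a margin beyond the scatter, and compound 2 lies lower still, also beyond the scatter.

Compound 4, `CC/C(=N\C#N)N(C)Cc1ccc(Cl)nc1`, has not been measured. It differs from compound 3 in one place: hydrogen in place of propyl on a saturated chain carbon, two bonds along the chain from a carbon with a double bond to nitrogen. Cut one bond further out, the same change reads pentyl to ethyl.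

Going by the values given here, one measured step bears on this. The step of a number 0.39 log units lower from compound 1 to compound 2 (beyond the scatter) removed an isopropyl from the amine nitrogen and brought a modest drop. The change from compound 3 to compound 4 removes a propyl from the chain, a loss of the same order of heavy atoms, so a drop in this assay is expected, probably larger than the modest one seen from compound 1 to compound 2 given the distance between compound 3 and compound 1 in this assay.

The expected step is a number 1.05 log units lower from compound 3 to compound 4 (beyond the scatter). For compound 4 the estimate in this assay is 1.25, within 0.85 to 1.65.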

Compound 4, partition coefficient: 1.12
Compound 4: the middle estimate sits 0.13 log units above what was measured, within the range that was stated.
By their numbers in this assay, from the lowest: compounds 2 and 4 (each within the scatter of the next); then compound 1; then compound 3.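

In this assay, cutting pentyl back to ethyl, with hydrogen in place of propyl on a saturated chain carbon, two bonds along the chain from a carbon with a double bond to nitrogen, gives a number 1.18 log units lower from compound 3 to compound 4 (beyond the scatter) as a large step. The only earlier step, a number 0.39 log units lower from compound 1 to compound 2 (beyond the scatter) on an amine nitrogen, was modest, so this chain position is the first place in the series where a single change is shown to move the read-out by a large step, and it does so with no ring, charge, hydrogen-bond donor or acceptor among the atoms that leave. Nothing on record explains why the step at this position is large.

The compounds shown leave open how the read-out runs through the intermediate propyl and butyl chains at this position, and so whether the fall is spread evenly along the chain or concentrated at one point. They also leave open how a longer chain such as heptyl, or a chain ending in an amine or a carboxylic acid, would read at the same place.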